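The compounds below may be only part of what the source reports. "The series", "measured", "known", "first", "only" and "open" are said of these compounds alone.

In a functional assay on HepG2 cells (Homo sapiens) for inhibition, read by MTT assay (on this read-out lower numbers stand for stronger inhibition and higher numbers for weaker inhibition), compound 1 `CCc1ccc(C(=O)Nc2ccc(Nc3ncnc4cc(OC)c(OC)cc34)cc2)cc1` gives 72000 nM. Compound 2 `COc1cc2ncnc(Nc3ccc(NC(=O)c4ccc(C(C)(C)C)cc4)cc3)c2cc1OC` gives > 100000 nM, which is a limit of the assay and not a number. On these data alone, compound 2 thus sits at the limit of > 100000 nM in this assay, at which 1 of the 2 values shown sits, so its true value is unknown and it cannot be ranked firmly against compound 1.

Compound 3 `COc1cc2ncnc(Nc3ccc(NC(=O)c4ccc(F)cc4)cc3)c2cc1OC` keeps the shared core and the amide and differs from compound 2 in one place: fluoro in place of tert-butyl on an aromatic carbon. This puts fluoro in place of tert-butyl on an aromatic carbon, para to a large group.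

Going by the values given here, only one measured step touches this carbon: an at least 1.3-fold higher number from compound 1 to compound 2 (0.14 log units; that floor lies within the scatter). That step swaps ethyl for tert-butyl, its floor lies within the scatter, and it says nothing directly about fluoro. The evidence is therefore thin. Among the compounds with values here, the one firm number nearby is that of compound 1 at 72000 nM, which suggests that a group other than tert-butyl here can give a measurable value. On that basis, a modest move towards a lower number is expected, an at least 1.6-fold lower number from compound 2 to compound 3 (0.22 log units; that floor lies within the scatter). For compound 3 the estimated value is 60000 nM, with an expected range of 20000 nM to 100000 nM.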

Compound 3, half-maximal inhibitory concentration: 15000 nM
For compound 3 the middle estimate is 4.0-fold (0.60 log units) above the measured one; measured number outside the range, below it.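

Replacing tert-butyl with fluoro on this aromatic carbon, para to a large group, gives an at least 6.6-fold lower number from compound 2 to compound 3 (0.82 log units; beyond the scatter) in this assay and so shows, as the earlier step within the scatter could not, that the value responds clearly to the group placed here. Fluoro also stands apart from ethyl at the same carbon, with a 4.8-fold lower number from compound 1 to compound 3 (0.68 log units; beyond the scatter) as the step, and this comparison rests on two real numbers, so compound 3 holds the lowest number of the three compounds shown, while the shared core and the amide stay the same throughout. The first of these steps is only a floor, because compound 2 carries a limit of the assay and not a number: the limit of > 100000 nM in this assay, at which 1 of the 3 values shown sits.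

With only tert-butyl, ethyl and fluoro at this carbon, the compounds shown cannot tell whether the numbers follow the size of the group or something particular to fluoro. On these data alone, how chloro, methoxy, an amine or a carboxylic acid would read at this carbon remains open, as does whether a change elsewhere on the molecule would give a similar step.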